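The source may hold more compounds than are shown below. What is called first, only, known or untested is meant among the compounds shown, and "the series" means these compounds.

Compound 1 `O=C(CCC1CCCC1)N(O)c1ccc(Cl)cc1` gives 100 ug/mL in a functional assay on cells (Cell line, Homo sapiens) for cytotoxicity, read by microscopy; on this read-out lower numbers stand for higher toxicity in this test and higher numbers for lower toxicity in this test.
Compound 2 `O=C(CC1CCCCC1)N(O)c1ccc(Cl)cc1` gives 50 ug/mL in this assay.

Compound 1 holds the higher of the two numbers, and its nearest neighbour is compound 2, which lies a 2.0-fold lower number from compound 1 to compound 2 (0.30 log units; within the scatter). Compound 3 `O=C(CCC1CCCCC1)N(O)c1ccc(Cl)cc1` is the next compound to be tested; it differs from compound 1 by cyclohexyl in place of cyclopentyl on a saturated chain carbon, two bonds along the chain from a carbonyl carbon. Within the data shown here, the only measured step that bears on this is the one from compound 1 to compound 2, which also exchanges a five-membered ring for a six-membered one and stays within the scatter. No shift beyond the scatter is therefore expected. Compound 3 is expected to give 70 ug/mL (range 35 ug/mL to 150 ug/mL), meaning an expected step of a 1.4-fold lower number from compound 1 to compound 3 (0.15 log units; within the scatter).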

Compound 3, minimum cytotoxic concentration: >= 4 ug/mL
Compound 3 gave a limit, no number; the forecaster's own chance of this, stated with the estimate: 5%; the middle value is on the limit's open side.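

In this assay compound 3 gives >= 4 ug/mL, which is a limit and not a number, so its step from compound 1 cannot be read. The compounds shown leave open whether cyclohexyl in place of cyclopentyl changes the minimum cytotoxic concentration of compound 1 at all.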